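A few compounds are considered here, and "the series" means these few. Any claim that something is new, unique, unknown or untested is made for them only; others in the source may bear on it.

Compound 1, `O=C(c1ccc(O)cc1O)[C@@H]1[C@H](C(=O)c2ccc(O)cc2O)[C@@H](c2ccccc2)[C@H]1c1ccccc1`, was tested in a functional assay on PC-3 cells (Homo sapiens) for cytotoxicity, read by MTT assay, with a stated time of 48 h, tested at 25 uM (a higher number here means a stronger effect of the compound at the concentration tested, a lower number a weaker effect), where compound 1 gives 78.8%. Going by the values given here, the only other measured compound is compound 2, `O=C(c1ccc(O)cc1O)[C@@H]1Cc2ccccc2[C@H](C(=O)c2ccc(O)cc2O)[C@@H]1c1ccccc1`, and in this assay compound 2 gives 73.4%. The two numbers lie within the usual scatter of each other, so compound 1 cannot be set apart from compound 2 on this reading; it simply stands alongside it at the upper part of the small set.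

Compound 3, `O=C(c1ccc(O)cc1O)[C@H]1[C@H](C(=O)c2ccc(O)cc2O)[C@@H](c2ccccc2)[C@@H]1c1ccccc1`, has not yet been measured. It differs from compound 1 as follows: the two compounds have the same atoms and bonds and differ only in configuration as drawn: 2 of 4 stereo elements differ; a stereocentre at a saturated ring carbon is drawn S in compound 1 and R in compound 3; a stereocentre at a saturated ring carbon is drawn R in compound 1 and S in compound 3. Among the compounds with values here, no measured pair in the set separates such a change in configuration alone, so there is no step from which its size could be read.

With nothing to anchor a stereochemical step, the expected step from compound 1 to compound 3 in this assay is a number 8.8 percentage points lower from compound 1 to compound 3 (within the scatter), which is taken to be small and most likely within the scatter. Compound 3 is therefore estimated to give 70% in this assay, with a range from 45% to 90%, the lower end allowing for the possibility that the changed configuration weakens the effect.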

Compound 3, a percentage reported as activity, at one concentration (the size of the read-out at that concentration, not a potency): 97.6%
Estimate against measurement, compound 3: 27.6 percentage points below; the measured number lies above the stated range.
By their numbers in this assay, from the lowest: compounds 2 and 1 (each within the scatter of the next); then compound 3.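

In this assay, going by these compounds alone, the reading shows a number 18.8 percentage points higher from compound 1 to compound 3 (beyond the scatter), and this is the first step in the set that can be read at all, since compound 1 and compound 2 differ in more than one place and gave no step. It shows that the arrangement of the same atoms on the shared core is enough on its own to move the cytotoxic reading at this concentration, with 2 of 4 stereo elements reversed and nothing entering or leaving. The change can be tied to configuration and to no group, because nothing else separates the pair: the fact that compounds 1 and 3 differ only in the configuration as drawn

Both stereocentres change together here, so the compounds shown do not tell whether one of them carries the step or whether it needs both, and a reading at a single concentration gives no potency for either compound. As far as these compounds go, whether this configuration keeps its edge when the shared core carries a different group, such as a methoxy group or an amine in place of a ring hydroxyl, also remains open.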